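Ethyl ester variant of the acetylated sulfanyl arm

The source may report more compounds than this note shows. Statements on the series, on what has been measured and on what is new or still open speak of the compounds shown alone.

Compound 1 `CC[C@H](C)[C@H](NCC(=O)NNC(=O)COc1ccc(-c2nc3ccccc3s2)cc1OC)C(=O)O` gives 3540 nM in a functional assay on HepG2 cells (Homo sapiens) for inhibition, read by MTT assay, with a stated time of 3 days (a higher number here means a weaker inhibitor, a lower number a stronger inhibitor), one of two numbers shown; the other, compound 2 `COc1cc(-c2nc3ccccc3s2)ccc1OCC(=O)NNC(=O)CN(C(C)=O)[C@@H](CS)C(=O)O`, gives 3420 nM in this assay and sits within the scatter of compound 1. Going by the values given here, the single measured step, a 1.0-fold lower number from compound 1 to compound 2 (0.01 log units; within the scatter), acts at the same position and stays within the scatter. Compound 3 `CCOC(=O)[C@H](CS)N(CC(=O)NNC(=O)COc1ccc(-c2nc3ccccc3s2)cc1OC)C(C)=O` differs from compound 1 as follows: acetyl(1-(ethoxycarbonyl)-2-sulfanylethyl)amino in place of (1-carboxy-2-methylbutyl)amino on a saturated chain carbon bound to a carbonyl carbon. Because a 1.0-fold lower number from compound 1 to compound 2 (0.01 log units; within the scatter) left the number essentially unchanged at this position, compound 3 is expected to stay near, with a 1.1-fold lower number from compound 1 to compound 3 (0.03 log units; within the scatter) not beyond the scatter. The estimate for compound 3 is 3300 nM, range 1400 nM to 8000 nM.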

Compound 3, half-maximal inhibitory concentration: 3010 nM
The estimate for compound 3 lay 1.1-fold (0.04 log units) above the measured number; the measured number falls inside the stated range.
By their numbers in this assay, from the lowest: compounds 3, 2 and 1 (each within the scatter of the next).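

Ethyl in place of hydrogen on an oxygen next to a carbonyl group gives a 1.1-fold lower number from compound 2 to compound 3 (0.06 log units; within the scatter) in this assay and thus does not separate the ester from the free acid at this position. The larger replacement, acetyl(1-(ethoxycarbonyl)-2-sulfanylethyl)amino in place of (1-carboxy-2-methylbutyl)amino, gives a 1.2-fold lower number from compound 1 to compound 3 (0.07 log units; within the scatter) at the same place, leaving all three arms within the scatter of one another. No supporting measurement bears on this result.

Going by these compounds, whether an amine or a longer chain in place of the sulfanyl group would keep the number within the scatter remains open. Replacing the acetyl group also remains untested in the compounds shown.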